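The source may report more compounds than this note shows. Statements on the series, on what has been measured and on what is new or still open speak of the compounds shown alone.

Measured compounds:
compound 1, `CN(C)c1ccc(CNC(=O)c2nc(Br)c3cccnc3c2N[C@H]2CC[C@H](N)CC2)cc1` — 4000 nM
compound 2, `O=C(NCCCNc1c(C(=O)NCc2ccc(F)cc2)nc(Br)c2cccnc12)c1ccccc1` — > 20000 nM

Both were run in a functional assay on MDA-MB-435 cells (Homo sapiens) for cytotoxicity, read by MTT assay, with a stated time of 72 h; a higher number here means a weaker inhibitor, a lower number a stronger inhibitor. Among the compounds with values here, compound 1 is the only compound of the two with a number: in this assay compound 1 gives 4000 nM. Compound 2 is reported only as a limit of the assay, > 20000 nM, with no number behind it; this is the limit of > 20000 nM in this assay, at which 1 of the 2 values shown sits. Within the data shown here, no pair of measured compounds differs in just one place, so nothing measured shows how far a single change shifts the read-out here.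

Compound 3, `N[C@H]1CC[C@H](Nc2c(C(=O)Nc3ccccc3)nc(Br)c3cccnc23)CC1`, differs from compound 1 in one place: phenyl in place of 4-(dimethylamino)benzyl on an amide-type nitrogen. The 4-(dimethylamino)benzyl group leaves and a phenyl enters on the amide-type nitrogen whose other neighbour is the carbonyl carbon.

With only compound 1 as a numbered point of reference, the step from compound 1 to compound 3 is expected to be a modest weakening, a 1.8-fold higher number from compound 1 to compound 3 (0.24 log units; within the scatter), with a step inside the scatter not excluded. Compound 3 is estimated to give 7000 nM in this assay, expected between 1500 nM and 20000 nM.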

Compound 3, half-maximal inhibitory concentration: 1000 nM
For compound 3 the middle estimate is 7.0-fold (0.85 log units) above the measured one; measured number outside the range, below it.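

In this assay, within the data shown here, the change on the amide-type nitrogen gives a 4.0-fold lower number from compound 1 to compound 3 (0.60 log units; beyond the scatter), the first single change in this set that can be read, and it lies beyond the usual scatter. It shows that the group on this nitrogen is not a silent position in this cell assay, and that the 4-(dimethylamino)benzyl group of compound 1 is not needed for the read-out, since compound 3 carries only a phenyl there and has the lower number. Nothing measured here accounts for the step, and a single step cannot separate the loss of the dimethylamino group from the loss of the carbon that links the ring to the nitrogen.

The compounds shown leave open which of those two parts carries the step, and a plain benzyl group on the same nitrogen would set the two apart. They also leave open whether a phenyl bearing a small substituent, such as a fluorine, a methoxy group or a carboxylic acid, would move the number further in either direction on this core.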